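The source may report more compounds than this note shows. Statements on the series, on what has been measured and on what is new or still open speak of the compounds shown alone.

Compound 1 `COc1c(OCCCCN2CCN(C)CC2)cc(O)c2c(=O)cc(-c3ccc(C)cc3)oc12` gives 3810 nM in a functional assay on A549 cells (Homo sapiens) for cytotoxicity, read by MTT assay, with a stated time of 72 h; a lower number here means a stronger inhibitor, a higher number a weaker inhibitor.
Compound 2 `COc1c(OCCCCN2CCN(C)CC2)cc(O)c2c(=O)cc(-c3ccc(C(F)(F)F)cc3)oc12` gives 2890 nM.
Compound 3 `O=c1cc(-c2ccccc2)oc2c(OCCCN3CCCC3)c(OCc3ccccc3)cc(O)c12` gives 4720 nM.

The three numbers lie within the usual scatter of one another, so compound 3 cannot be set apart from compound 1 or compound 2 on these data; it shares with them a common core carrying a basic amine on a chain attached through an oxygen.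

Compound 4 `CCN(CC)CCCCOc1c(OCc2ccccc2)cc(O)c2c(=O)cc(-c3ccccc3)oc12` differs from compound 3 in one place: (diethylamino)methyl in place of pyrrolidin-1-yl on a saturated chain carbon, three bonds along the chain from an oxygen on an aromatic ring. The only measured step among these compounds is a change on the aromatic ring at the other end of the core, a 1.3-fold lower number from compound 1 to compound 2 (0.12 log units; within the scatter), and it does not touch the chain amine. Within the data shown here, no measured pair varies the amine itself, so nothing here bears directly on the step from compound 3 to compound 4. Among the measured compounds shown here, with one amine of the same kind exchanged for another of similar size, and with the one available step lying within the scatter, the expected change in this assay is none beyond the scatter, a 1.0-fold lower number from compound 3 to compound 4 (0.02 log units; within the scatter). Compound 4 is therefore estimated at 4500 nM, with a range from 2000 nM to 10000 nM.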

Compound 4, half-maximal inhibitory concentration: 3910 nM
For compound 4 the middle estimate is 1.2-fold (0.06 log units) above the measured one, and the stated range covers the measured number.
By their numbers in this assay, from the lowest: compounds 2, 1, 4 and 3 (each within the scatter of the next).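

In this assay, exchanging pyrrolidin-1-yl for (diethylamino)methyl on this saturated chain carbon gives a 1.2-fold lower number from compound 3 to compound 4 (0.08 log units; within the scatter), the first measured step among these compounds that touches the amine end of the chain rather than the aromatic ring at the other end of the core. The change can also be read as 3-(pyrrolidin-1-yl)propyl to 4-(diethylamino)butyl, so, for this one pair, replacing a ring amine on a propyl chain with an open-chain amine on a butyl chain moves the number no further than the scatter, and the amine end of the chain tolerates at least this one exchange without a measurable difference. Nothing among the data shown gives a reason for this outcome.

From the compounds shown here alone, what remains open is whether a morpholine, a primary amine or a carboxylic acid at the end of the chain would shift the number beyond the scatter, since both amines in this pair gave values of the same order. Going by these compounds, it is also open whether a shorter chain, such as an ethyl link to the diethylamino group, would behave the same way, as this pair alters the ring and the chain length together.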